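Hydroxy to Methoxy: Expected Growth Inhibition of Compound 3

A few compounds are considered here, and "the series" means these few. Any claim that something is new, unique, unknown or untested is made for them only; others in the source may bear on it.

Measured compounds:
compound 1 `Cc1cc(O)nc(NC(=S)NC(=O)c2c(-c3ccc(Cl)cc3Cl)noc2C)n1`: -9.78%
compound 2 `CSc1cc(C)nc2n/c(=N/C(=O)c3c(-c4ccc(Cl)cc4Cl)noc3C)sn12`: 37.5%

Of the compounds shown here, two have been tested in a functional assay on the whole organism (strain L.) for inhibition, with Echinochloa crus-galli as the target, with a stated time of 72 h, tested at 10 mg/L; on this read-out lower numbers stand for less inhibition of growth and higher numbers for more inhibition of growth at the one concentration tested. Compound 1 gives -9.78%, the lowest of the two numbers. Compound 2 gives 37.5%, a number that lies beyond the scatter above compound 1; since the two structures differ in more than one place, only these two values can be compared. Compound 3 `COc1cc(C)nc(NC(=S)NC(=O)c2c(-c3ccc(Cl)cc3Cl)noc2C)n1` has not yet been measured. It differs from compound 1 by methyl in place of hydrogen on an oxygen on an aromatic ring. Among the measured compounds shown here, no measured pair shows this change, so the expectation rests on compound 1 alone. The expected step is small, a number 14.8 percentage points higher from compound 1 to compound 3 (beyond the scatter), a slight rise that may well stay within the scatter. Compound 3 is therefore expected to give 5%, with a range from -15% to 30%.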

Compound 3, percent growth inhibition at one concentration: 12.3%
Compound 3: the middle estimate sits 7.3 percentage points below what was measured, within the range that was stated.
By their numbers in this assay, from the lowest: compound 1; then compound 3; then compound 2.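

Moving from the 4-hydroxy-6-methylpyrimidin-2-yl group to the 4-methoxy-6-methylpyrimidin-2-yl group gives, in this assay, a number 22.1 percentage points higher from compound 1 to compound 3 (beyond the scatter) for this one change. This is the only pair shown that differs in one place, so it gives the first direct reading of this oxygen on the aromatic ring: methyl in place of hydrogen, a single added carbon, moves the read-out beyond the usual scatter. The measurements at hand offer no explanation for this step.

A single step cannot show whether the rise continues as the group on this oxygen grows or is particular to methyl. The compounds shown leave open how an ethyl or a longer chain on this oxygen, or an amine in place of the hydroxy, would read.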